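From cyclohexyl to sec-butyl on the amine nitrogen

This account rests on a few compounds, and the source may have more. Where it says the series, first, only, none or still open, it means among the compounds named here.

Among the measured compounds shown here, in a functional assay on Caco-2 cells (Homo sapiens) for inhibition, read by sulforhodamine B assay, with a stated time of 72 h (on this read-out lower numbers stand for stronger inhibition and higher numbers for weaker inhibition), compound 1 (`COc1cc(/C=C/C(=O)/C=C(/C=C/c2ccc(OC(C)=O)c(OC)c2)NC2CCCCC2)ccc1OC(C)=O`) gives 4400 nM and holds the only true number so far. Compound 2 (`C=CCNC(=C\C(=O)/C=C/c1ccc(O)c(OC)c1)/C=C/c1ccc(O)c(OC)c1`) stands at > 25000 nM as a limit of the assay and not a number. Compound 1 therefore cannot yet be placed against a measured neighbour.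

Compound 3 (`CCC(C)NC(=C\C(=O)/C=C/c1ccc(OC(C)=O)c(OC)c1)/C=C/c1ccc(OC(C)=O)c(OC)c1`) differs from compound 1 in one place (sec-butyl in place of cyclohexyl on an amine nitrogen) with sec-butyl in place of cyclohexyl on an amine nitrogen. For the measured compounds named here, no measured pair shows what this change does, so the expectation rests on compound 1 at 4400 nM alone. The expected step (a 1.4-fold higher number from compound 1 to compound 3 (0.13 log units; within the scatter)) in this assay stays within the scatter and leans slightly towards weaker inhibition. For compound 3 the estimated value is 6000 nM with an expected range from 2500 nM to 15000 nM for now.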

Compound 3, half-maximal inhibitory concentration: 24000 nM
Compound 3: middle estimate off by 4.0-fold (0.60 log units), on the low side; measured number outside the range, above it.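

In this assay, among the compounds shown here, the first measured step at this amine nitrogen reads a 5.5-fold higher number from compound 1 to compound 3 (0.74 log units; beyond the scatter), so the group placed here does change the read-out. Compound 1 now has a measured neighbour, and of the two groups compared, cyclohexyl gives the stronger inhibition and sec-butyl the weaker. The number for compound 3 lies close to the end of the range that the assay reports as a number: the limit of > 25000 nM in this assay, at which 1 of the 3 values shown sits.

This single pair changes ring and carbon count together, and the compounds shown do not separate the two; a cyclopentyl or n-butyl group on this nitrogen would. Also open, from the compounds shown here alone, is whether a larger ring such as cycloheptyl, or a chain carrying a hydroxyl group, would give a lower number than compound 1.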